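A few compounds are considered here, and "the series" means these few. Any claim that something is new, unique, unknown or untested is made for them only; others in the source may bear on it.

Among the two compounds that have been measured, compound 1 `CC1=C(C)C(=O)C(CCCCCCCCCCn2cc(C[C@H](O)COCCOC[C@@H](O)Cc3ccc(-c4ccccc4)cc3)nn2)=C(C)C1=O` stands with the lowest number in a functional assay on HCT-116 cells (Homo sapiens) for inhibition, read by MTT assay, with a stated time of 72 h; a higher number here means a weaker inhibitor of growth, a lower number a stronger inhibitor of growth: in this assay compound 1 gives 900 nM. The other measured compound, compound 2 `O[C@H](COCCOC[C@@H](O)Cc1cn(Cc2ccc3ccccc3c2)nn1)Cc1ccc(-c2ccccc2)cc1`, gives 8600 nM in this assay, and the gap between the values of compound 1 and compound 2 lies beyond the scatter of repeated measurements. Compound 3 `COC1=C(C)C(=O)C(CCCCCCCCCCn2cc(C[C@H](O)COCCOC[C@@H](O)Cc3ccc(-c4ccccc4)cc3)nn2)=C(C)C1=O` has not yet been measured. It differs from compound 1 in one place: methoxy in place of methyl on a double-bonded ring carbon of the six-membered non-aromatic ring of compound 1. Among the compounds with values here, no pair of measured compounds isolates this exchange, so nothing is known about its size from the numbers in hand. A change of this kind, one heavy atom added at the edge of the ring, is expected to move the value little, with a step from compound 1 to compound 3 of no change at the digits printed from compound 1 to compound 3 (within the scatter), which is not beyond the scatter. Compound 3 is therefore estimated at 900 nM in this assay, within a range of 350 nM to 2500 nM.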

Compound 3, concentration for 50% growth inhibition: 4000 nM
Compound 3: middle estimate off by 4.4-fold (0.65 log units), on the low side, and the stated range ends below it.
By their numbers in this assay, from the lowest: compound 1; then compound 3; then compound 2.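

Within the data shown here, the exchange of methyl for methoxy on a double-bonded ring carbon of the six-membered non-aromatic ring is the first single change that can be read here, and in this assay it gives a 4.4-fold higher number from compound 1 to compound 3 (0.65 log units; beyond the scatter). The earlier compounds shown here said nothing about this ring carbon, whereas this pair shows that it is not indifferent to what it carries: with the rest of compound 1 unchanged, adding one oxygen atom, counted as one hydrogen-bond acceptor, and so going from one heavy atom to two in this group, is enough to give a weaker inhibitor of growth. No measurement available here offers an explanation for this step.

On these data alone, this single pair cannot separate the added oxygen from the added heavy atom, so it remains open whether an ethyl group, which has two heavy atoms and no oxygen, would behave like methoxy, or whether a hydroxy group or a chlorine atom would fall closer to methyl. As far as these compounds go, it also remains open whether methoxy in place of methyl would give a step of similar size on the other ring atoms that bear a methyl group.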